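This account rests on a few compounds, and the source may have more. Where it says the series, first, only, none or still open, it means among the compounds named here.

Working notes on the series in a functional assay on CHO-K1 cells for antagonist activity at C-X-C chemokine receptor type 3 (Homo sapiens), read by FLIPR, with a stated time of 10 min; a lower number here means a stronger inhibitor, a higher number a weaker inhibitor. Compound 1 `O=C(Cn1cnc2cccnc21)N1CCN(c2ncccc2-c2nc3ccccc3[nH]2)CC1` gives 496 nM and compound 2 `O=C(Cn1cnc2cccnc21)N1CCN(c2ncsc2-c2nc3ccccc3[nH]2)CC1` gives 4210 nM. Compound 3 `CCOc1ncc(-c2nc(C(F)(F)F)sc2N2CCN(C(=O)Cn3ncc4cccnc43)[C@H](C)C2)cn1` gives 4.1 nM, the lowest of the three numbers; its gaps to compound 1 and to compound 2 both lie beyond the scatter. No single-point steps between measured compounds are shown, so the change to compound 4 `CCOc1ncc(-c2nc(C(F)(F)F)sc2N2CCN(C(=O)Cn3nc(C)nc3C)[C@H](C)C2)cn1` has no measured precedent here. The change is a group of 7 heavy atoms (4 carbon, 3 nitrogen; one five-membered aromatic ring with 3 hetero atoms) in place of a group of 9 heavy atoms (6 carbon, 3 nitrogen; one five-membered aromatic ring with 2 hetero atoms, one six-membered aromatic ring with 1 hetero atom), on a saturated chain carbon bound to a carbonyl carbon. For the measured compounds named here, with no comparable step to lean on, a modest move toward a higher number is expected from compound 3 to compound 4 in this assay, as a 2.9-fold higher number from compound 3 to compound 4 (0.47 log units; beyond the scatter). Compound 4 is estimated at 12 nM, within a range of 3 nM to 60 nM.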

Compound 4, half-maximal inhibitory concentration: 7 nM
Beside the measured number, compound 4's estimate is 1.7-fold (0.23 log units) above it, within the range that was stated.
By their numbers in this assay, from the lowest: compounds 3 and 4 (each within the scatter of the next); then compound 1; then compound 2.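

In this assay, the step of a 1.7-fold higher number from compound 3 to compound 4 (0.23 log units; within the scatter) lies within the scatter, so on a saturated chain carbon bound to a carbonyl carbon this assay does not separate the 3,5-dimethyl-1H-1,2,4-triazol-1-yl group from the two-ring group it replaces. For the compounds shown here, for this pair, the six-membered aromatic ring is thus not needed to keep the number in this range, which the earlier compounds could not show. Nothing at hand gives a reason for this result. Open, as far as these compounds go, is how a dimethylamino group or a carboxylic acid on the same carbon would read, and whether the triazole needs its two methyl groups.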